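Phenyl in Place of Ethyl on a Shared Core

The compounds below may be only part of what the source reports. "The series", "measured", "known", "first", "only" and "open" are said of these compounds alone.

Compound 1 `CCCc1nc(C)c2c(C)nn(CCC)c(=O)n12` and compound 2 `CC(C)(C)c1nc(Br)c2cnnc(O)n12` were both examined in a functional assay for inhibition, with Homo sapiens as the target; on this read-out higher numbers stand for weaker inhibition and lower numbers for stronger inhibition. For compound 1 this assay records only a limit, > 48000 nM, and not a number (the limit of > 48000 nM in this assay, at which 1 of the 2 values shown sits). Compound 2 gives 19000 nM in this assay. For the measured compounds named here, no two of the measured compounds differ in a single place, so no measured step between them can be quoted, and the two values stand side by side without further comparison. Compound 3 `CCCc1nc(C)c2c(C)nn(Cc3ccccc3)c(=O)n12` has not yet been tested. It differs from compound 1 by phenyl in place of ethyl on a saturated chain carbon bound to an aromatic nitrogen, which one bond further out reads as propyl to benzyl. Since compound 1 is known only as a limit, the step from compound 1 to compound 3 is expected to run toward stronger inhibition, estimated as an at least 1.6-fold lower number from compound 1 to compound 3 (0.20 log units; that floor lies within the scatter). Compound 3 is accordingly expected to give about 30000 nM in this assay, within a range of 8000 nM to 100000 nM.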

Compound 3, half-maximal inhibitory concentration: > 48000 nM
Compound 3: only a limit was reported (the forecaster's own chance of this, stated with the estimate: 45%); middle value at least 1.6-fold (0.20 log units) from the limit.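

In this assay compound 3 is recorded only as a limit, as compound 1 is, so no step from compound 1 to compound 3 can be read: the limit of > 48000 nM in this assay, at which 2 of the 3 values shown sit.

The compounds shown leave open whether phenyl in place of ethyl at this place changes inhibition at all.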